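Phenyl in place of thiophen-3-yl on a shared core

The source may report more compounds than this note shows. Statements on the series, on what has been measured and on what is new or still open speak of the compounds shown alone.

Three compounds that share one core and differ only in one aromatic group have been tested in a functional assay on CCRF-CEM cells (Homo sapiens), read by MTT assay, with a stated time of 72 h (on this read-out higher numbers stand for weaker inhibition and lower numbers for stronger inhibition), so far. Compound 1 (`Cc1nc(N)c2c(-c3ccco3)cn([C@@H]3O[C@H](CO)[C@@H](O)[C@H]3O)c2n1`), with furan-2-yl, reads > 100000 nM as a limit and not a number. Compound 2 (`Cc1nc(N)c2c(-c3ccoc3)cn([C@@H]3O[C@H](CO)[C@@H](O)[C@H]3O)c2n1`), with furan-3-yl, reads > 100000 nM as a limit too. Compound 3 (`Cc1nc(N)c2c(-c3ccsc3)cn([C@@H]3O[C@H](CO)[C@@H](O)[C@H]3O)c2n1`), with thiophen-3-yl, reads > 20000 nM as a limit as well. Compound 3 therefore has no number of its own and stands at the limit of > 20000 nM in this assay, at which 1 of the 3 values shown sits, for now.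

Compound 4 (`Cc1nc(N)c2c(-c3ccccc3)cn([C@@H]3O[C@H](CO)[C@@H](O)[C@H]3O)c2n1`) has not yet been measured and carries phenyl in place of thiophen-3-yl on an aromatic carbon. The nearest measured changes also exchange one aromatic group for another: a step that the two limits leave unreadable from compound 1 to compound 3 and a step that the two limits leave unreadable from compound 2 to compound 3 lead to compound 3, and a step that the two limits leave unreadable from compound 1 to compound 2 links the two furan compounds. None of them has a size that can be carried over. Compound 3 offers only its limit of > 20000 nM as a guide, and compound 4 is expected to report a limit too, with no direction readable. What is expected is a step that the limit leaves unreadable from compound 3 to compound 4 in this assay for this change. Compound 4 is estimated at 60000 nM with an expected range from 20000 nM to 100000 nM as its span.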

Compound 4, half-maximal inhibitory concentration: > 20000 nM
Compound 4 gave a limit, no number (the forecaster's own chance of this, stated with the estimate: 85%); the middle value lies beyond the limit too.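

In this assay, compound 4 gave only a limit and no number, as did compound 1, compound 2 and compound 3, so no step among these four compounds can be read. The compounds shown leave open whether furan-2-yl, furan-3-yl, thiophen-3-yl and phenyl differ at all on the shared core in this assay.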